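Inverting the Ring Stereocentre of Compound 2

The source may hold more compounds than are shown below. What is called first, only, known or untested is meant among the compounds shown, and "the series" means these compounds.

Measured in an assay for inhibition of Tryptophan 2,3-dioxygenase (Homo sapiens), with stated times of 10 min and 60 min, tested at 100 uM; a higher number here means a stronger effect of the compound at the concentration tested, a lower number a weaker effect:
Compound 1 `FC(F)(F)c1cc(NC[C@H]2CCCN2)c2cn[nH]c2c1` gives 84%
Compound 2 `FC(F)(F)c1cc(NC[C@@H]2CCCCN2)c2cn[nH]c2c1` gives 88%

Within the data shown here, compound 2 stands at the top of these two numbers, yet the only measured step, a number 4 percentage points higher from compound 1 to compound 2 (within the scatter), lies within the scatter, so compound 1 and compound 2 are effectively alike. Compound 3 `FC(F)(F)c1cc(NC[C@H]2CCCCN2)c2cn[nH]c2c1` differs from compound 2 as follows: the two compounds have the same atoms and bonds and differ only in configuration as drawn: 1 of 1 stereo elements differ; a stereocentre at a saturated ring carbon is drawn S in compound 2 and R in compound 3. Among the measured compounds shown here, that measured step swapped ring size, not configuration, so no measured step bears on this change. Compound 3 is therefore expected to give 75%, in the range 35% to 95%, because the mirror arrangement could weaken binding while compound 2 gives 88%. The expected step is a number 13 percentage points lower from compound 2 to compound 3 (beyond the scatter).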

Compound 3, a percentage reported as inhibition, at one concentration (the size of the read-out at that concentration, not a potency): 90%
For compound 3 the middle estimate is 15 percentage points below the measured one; low and high end bracket the measured number.
By their numbers in this assay, from the lowest: compounds 1, 2 and 3 (each within the scatter of the next).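

In this assay, compounds 2 and 3 test configuration alone: the fact that compounds 2 and 3 differ only in the configuration as drawn. Inverting the stereocentre at the saturated ring carbon gives a number 2 percentage points higher from compound 2 to compound 3 (within the scatter) and so shows no readable dependence on configuration at this one concentration. Piperidin-2-yl in place of pyrrolidin-2-yl, now read with the other configuration, gives a number 6 percentage points higher from compound 1 to compound 3 (within the scatter) and likewise leaves the compounds alike.

Still open, going by these compounds, is whether a methyl group on the ring nitrogen, or an open-chain amine in place of the ring, would keep this level of inhibition. A reading at a single concentration also leaves open whether these compounds would differ in the size of their effect at other concentrations.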